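The source may hold more compounds than are shown below. What is called first, only, known or untested is meant among the compounds shown, and "the series" means these compounds.

Measured so far:
Compound 1, `Cc1cc(=O)n(-c2ccc(Br)cc2F)nc1C(=O)Nc1ccc(Oc2ncnc3ccsc23)c(F)c1`: 3350 nM
Compound 2, `Cc1cc(=O)n(-c2ccccc2C(F)(F)F)nc1C(=O)Nc1ccc(Oc2ncnc3sccc23)c(F)c1`: 14700 nM
Compound 3, `O=C(Nc1ccc(Oc2ncnc3ccsc23)c(F)c1)c1nn(-c2ccc(F)c(Cl)c2)ccc1=O`: 10600 nM

In a functional assay on HepG2 cells (Homo sapiens) for cytotoxicity, read by MTT assay, with a stated time of 72 h (on this read-out higher numbers stand for weaker inhibition and lower numbers for stronger inhibition), compound 3 holds the second highest of the three numbers. Its nearest neighbour is compound 2, whose number lies within the scatter of its own, while compound 1 sits further off, with a lower number beyond the scatter. The next compound, compound 4 `O=C(Nc1ccc(Oc2ncnc3ccsc23)c(F)c1)c1nn(-c2ccccc2)ccc1=O`, differs from compound 3 in one place: phenyl in place of 3-chloro-4-fluorophenyl on an aromatic nitrogen. For the measured compounds named here, no measured pair shows this change, so its effect is unknown. Going by the values given here, since only two substituents on that ring leave, the step from compound 3 to compound 4 in this assay is expected to be small, and no direction beyond the scatter is expected: a 1.1-fold higher number from compound 3 to compound 4 (0.05 log units; within the scatter). Compound 4 is thus expected to give 12000 nM in this assay, with a range from 4000 nM to 40000 nM.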

Compound 4, half-maximal inhibitory concentration: 13500 nM
For compound 4 the middle estimate is 1.1-fold (0.05 log units) below the measured one; the measured number falls inside the stated range.
By their numbers in this assay, from the lowest: compound 1; then compounds 3, 4 and 2 (each within the scatter of the next).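

In this assay the first pair differing in one place gives a 1.3-fold higher number from compound 3 to compound 4 (0.11 log units; within the scatter) and so stays within the scatter. On this aromatic nitrogen, taking away both the chlorine and the fluorine of the 3-chloro-4-fluorophenyl therefore leaves the number unchanged within that scatter, and the bare phenyl serves equally here. No evidence is available that bears on this result.

From the compounds shown here alone, it remains open whether an amine or a carboxylic acid on that phenyl would move the number beyond the scatter. Going by these compounds, compound 1 differs from compound 3 in more than one place, so what sets its lower number apart also stays open.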